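Pyridin-3-yl in place of ethyl: what to expect

The source may hold more compounds than are shown below. What is called first, only, known or untested is meant among the compounds shown, and "the series" means these compounds.

Compound 1 `Cn1nc(-c2ccnc(Nc3cccc(S(N)(=O)=O)c3)n2)c2ccccc21` gives 2270 nM in a functional assay on MCF7 cells (Homo sapiens) for antiproliferative activity, read by MTT assay, with a stated time of 72 h; on this read-out higher numbers stand for weaker inhibition of growth and lower numbers for stronger inhibition of growth.
Compound 2 `CCn1nc(-c2ccnc(Nc3ccc(O)cc3)n2)c2ccccc21` gives 5780 nM in this assay.
Compound 3 `CCCn1nc(-c2ccnc(Nc3cccc(S(N)(=O)=O)c3)n2)c2ccccc21` gives 4260 nM in this assay.

Among these three numbers compound 3 stands second highest; its nearest neighbour is compound 2 and its furthest compound 1, and both gaps lie within the scatter, so no order can be read from them. Compound 4 `NS(=O)(=O)c1cccc(Nc2nccc(-c3nn(Cc4cccnc4)c4ccccc34)n2)c1` differs from compound 3 in one place: pyridin-3-yl in place of ethyl on a saturated chain carbon bound to an aromatic nitrogen. Among the measured compounds shown here, the only measured step touching this position, a 1.9-fold higher number from compound 1 to compound 3 (0.27 log units; within the scatter), stayed within the scatter, but it only lengthened the chain and says nothing about a ring entering here. No direction beyond the scatter is therefore expected. The estimate for compound 4 is 3500 nM, ranging from 900 nM to 13000 nM. The expected step is a 1.2-fold lower number from compound 3 to compound 4 (0.09 log units; within the scatter).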

Compound 4, concentration for 50% growth inhibition: 5270 nM
Compound 4: middle estimate off by 1.5-fold (0.18 log units), on the low side, within the range that was stated.
By their numbers in this assay, from the lowest: compounds 1, 3, 4 and 2 (each within the scatter of the next, the first and the last beyond it).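

In this assay pyridin-3-yl in place of ethyl gives a 1.2-fold higher number from compound 3 to compound 4 (0.09 log units; within the scatter), so a ring can stand at this position without a change that can be told from the scatter. Pyridin-3-yl in place of hydrogen on the same carbon gives a 2.3-fold higher number from compound 1 to compound 4 (0.37 log units; beyond the scatter) and marks a modest weakening of growth inhibition, the first step at this position to pass the scatter. Nothing available explains either step. Going by these compounds, it remains open whether a plain phenyl ring would match pyridin-3-yl here, which would show whether the ring nitrogen matters. An amine or a carboxylic acid at the end of the chain also remains untested among these compounds.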